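The source may hold more compounds than are shown below. What is called first, only, known or untested is meant among the compounds shown, and "the series" means these compounds.

Measured compounds:
compound 1, `COc1ccc(-c2cc(NNC(=O)Nc3cc(Cl)nc(Cl)c3)nc3c2c(C)nn3C)cc1`, in a functional assay on SW620/5-FU cells (Homo sapiens) for cytotoxicity, read by MTT assay, with a stated time of 48 h, in the presence of a further agent that is not named here (a lower number here means that less compound is needed, a higher number that more compound is needed for the effect), gives 9700 nM;
compound 2, `Cc1nn(C)c2nc(NNC(=O)Nc3cc(Cl)nc(Cl)c3)cc(C3CCCCC3)c12`, in this assay gives 22000 nM.

For the measured compounds named here, compound 2 holds the highest of the two numbers so far, and its only neighbour is compound 1, from which it is separated by a 2.3-fold higher number from compound 1 to compound 2 (0.36 log units; beyond the scatter), a change that put cyclohexyl in place of 4-methoxyphenyl on an aromatic carbon.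

The next compound, compound 3, `Cc1cc(NNC(=O)Nc2cc(Cl)nc(Cl)c2)nc2c1c(C)nn2C`, has not yet been measured. It differs from compound 2 by methyl in place of cyclohexyl on an aromatic carbon.

Going by the values given here, only one measured step is available for comparison, and it concerns a different swap at the same aromatic carbon. It was of modest size and went toward a higher number. Removing a ring in favour of a single carbon is a further change in the same place, so a step of similar modest size toward a higher number is expected in this assay, namely a 1.4-fold higher number from compound 2 to compound 3 (0.13 log units; within the scatter). Compound 3 is therefore estimated at 30000 nM, with a range from 10000 nM to 90000 nM.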

Compound 3, half-maximal effective concentration: > 100000 nM
Compound 3 gave a limit, no number; the forecaster's own chance of this, stated with the estimate: 25%; at least 3.3-fold (0.52 log units) between middle value and limit.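

Compound 1 and compound 2 both carry a ring at this aromatic carbon, and exchanging one ring for the other moved the number only modestly. Methyl, which brings no ring, gives an at least 4.5-fold higher number from compound 2 to compound 3 (0.65 log units; beyond the scatter) and an at least 10-fold higher number from compound 1 to compound 3 (1.01 log units; beyond the scatter), so in this assay going from either ring to methyl moves the number further than exchanging one ring for the other. Compound 3 gives a limit of the assay, not a number: the limit of > 100000 nM in this assay, at which 1 of the 3 values shown sits.

The compounds shown cannot separate the loss of a ring from the loss of heavy atoms, as methyl differs from cyclohexyl in both. A butyl chain at this aromatic carbon, which has no ring, would speak to that question, and an amine there would extend the comparison beyond groups of carbon only.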